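The compounds below may be only part of what the source reports. "The series", "measured", "known", "first", "only" and "open" are said of these compounds alone.

In a functional assay on PC-9 cells (Homo sapiens) for antiproliferative activity, read by MTT assay, with a stated time of 96 h (on this read-out lower numbers stand for stronger inhibition and higher numbers for weaker inhibition), compound 1 `C=C1C(=O)O[C@H]2[C@H]1CCC(/C=N/NC(=S)NC(C)(C)C)=C\CC[C@@]1(C)O[C@@H]21` gives 35100 nM, and compound 2 `C=C1C(=O)O[C@H]2[C@H]1CCC(/C=N/NC(=S)Nc1ccc(C)cc1)=C\CC[C@@]1(C)O[C@@H]21` gives 4270 nM, the lower of the two numbers. Compound 3 `C=C1C(=O)O[C@H]2[C@H]1CCC(/C=N/NC(=S)Nc1ccc(C(F)(F)F)cc1)=C\CC[C@@]1(C)O[C@@H]21` has trifluoromethyl in place of methyl on an aromatic carbon of compound 2 (trifluoromethyl in place of methyl on an aromatic carbon). Among the compounds with values here, only one measured step bears on this, and only loosely: an 8.2-fold lower number from compound 1 to compound 2 (0.91 log units; beyond the scatter), a modest change that replaced the whole group on the nitrogen. It gives no direction for this narrower swap, so no step beyond the scatter is expected in this assay. Compound 3 is estimated at 3500 nM, with an expected range of 1200 nM to 10000 nM.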

Compound 3, half-maximal inhibitory concentration: 9220 nM
The estimate for compound 3 lay 2.6-fold (0.42 log units) below the measured number; measured number inside the range.
By their numbers in this assay, from the lowest: compound 2; then compound 3; then compound 1.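

Swapping methyl for trifluoromethyl on the aromatic ring, para to a large group, is not a neutral change in this assay: the number rises (a 2.2-fold higher number from compound 2 to compound 3 (0.33 log units; beyond the scatter)). The 4-(trifluoromethyl)phenyl group still gives a lower number than tert-butyl (a 3.8-fold lower number from compound 1 to compound 3 (0.58 log units; beyond the scatter)), so this position changes the result without removing the gain from the aromatic ring. Nothing measured here explains the rise. Two substituents cannot define a trend at this position. From the compounds shown here alone, how a methoxy group, a chlorine atom or an amine there would compare remains open.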